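Moving the Chlorine Around the Ring in Compound 3

The compounds below may be only part of what the source reports. "The series", "measured", "known", "first", "only" and "open" are said of these compounds alone.

Compound 2 `CC1=NC(c2cn(S(=O)(=O)c3cccc(Cl)c3)c3ccc(C)cc23)CN1` is the weaker of two compounds in an assay on isolated protein for inhibition of kallikrein-7 (Homo sapiens), read by fluorescence, with stated times of 10 min and 30 min (a lower number here means a stronger inhibitor, a higher number a weaker inhibitor), giving 30000 nM, while compound 1 `CC1=NC(c2cn(S(=O)(=O)c3ccc(Cl)cc3)c3ccc(C)cc23)CN1` gives 1900 nM. Among the compounds with values here, the only measured step, a 16-fold higher number from compound 1 to compound 2 (1.20 log units; beyond the scatter), shows that shifting the chlorine on this ring can matter greatly. Compound 3 `CC1=NC(c2cn(S(=O)(=O)c3ccccc3Cl)c3ccc(C)cc23)CN1` differs from compound 2 by 2-chlorophenyl in place of 3-chlorophenyl on a sulfonyl sulfur. Within the data shown here, no measured step covers this particular move, so its direction is uncertain, and the earlier step only warns that the change may be large in this assay. Compound 3 is therefore expected near 15000 nM, ranging from 2000 nM to 60000 nM, which would be a step of a 2.0-fold lower number from compound 2 to compound 3 (0.30 log units; within the scatter).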

Compound 3, half-maximal inhibitory concentration: 1200 nM
Compound 3: middle estimate off by 13-fold (1.10 log units), on the high side; the measured number lies below the stated range.
By their numbers in this assay, from the lowest: compounds 3 and 1 (each within the scatter of the next); then compound 2.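

In this assay, the 2-chlorophenyl group recovers what the 3-chlorophenyl group lost, with a 25-fold lower number from compound 2 to compound 3 (1.40 log units; beyond the scatter) as the step. Against the 4-chlorophenyl group, the change is a 1.6-fold lower number from compound 1 to compound 3 (0.20 log units; within the scatter) and so gives no order between those two, leaving compound 2 the weakest of the three. The data offer no explanation for why the 3-chlorophenyl group stands apart. Still open, on these data alone, is whether this pattern belongs to chlorine alone. A methoxy group, an amine or a carboxylic acid on this ring could follow it or break it.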